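The source may hold more compounds than are shown below. What is called first, only, known or untested is meant among the compounds shown, and "the series" means these compounds.

Compounds measured so far:

compound 1, `CCCCn1cnc2c(Nc3ccc(Cl)cc3)nc(N[C@H]3CC[C@H](N)CC3)nc21`, 2100 nM in a functional assay on MCF7 cells (Homo sapiens) for inhibition, read by fluorescence, with a stated time of 72 h; on this read-out lower numbers stand for stronger inhibition of growth and higher numbers for weaker inhibition of growth
compound 2, `CCCCn1cnc2c(Nc3cccc(Cl)c3)nc(N[C@H]3CC[C@H](N)CC3)nc21`, 2000 nM
compound 3, `COc1ccc(Nc2nc(N[C@H]3CC[C@H](N)CC3)nc3c2ncn3CCC(C)C)c(OC)c1`, 6300 nM

All three share one core, carrying a chain on an aromatic nitrogen and a substituted aniline. Compound 2 gives the lowest number of the three in this assay, although compound 1 lies within the scatter of it, as the step of a 1.1-fold lower number from compound 1 to compound 2 (0.02 log units; within the scatter) shows; compound 3 stands clearly higher than compound 2, but it differs from compound 2 in both the chain and the aniline, so that gap cannot be laid to either change alone.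

Compound 4, `N[C@H]1CC[C@H](Nc2nc(Nc3cccc(Cl)c3)c3ncn(Cc4ccccc4)c3n2)CC1`, keeps the aniline of compound 2 and alters only the chain: phenyl in place of propyl on a saturated chain carbon bound to an aromatic nitrogen. No measured pair isolates this change, and the only single step shown, from compound 1 to compound 2, concerns the aniline and is within the scatter. With nothing to point either way, no step beyond the scatter is expected for no change at the digits printed from compound 2 to compound 4 (within the scatter) in this assay. Compound 4 is therefore estimated at 2000 nM, with a range from 600 nM to 7000 nM.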

Compound 4, concentration for 50% growth inhibition: 3600 nM
Compound 4: the middle estimate sits 1.8-fold (0.26 log units) below what was measured, within the range that was stated.
By their numbers in this assay, from the lowest: compounds 2, 1, 4 and 3 (each within the scatter of the next, the first and the last beyond it).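

This is the first change shown at this position on its own: in this assay, phenyl in place of propyl on a saturated chain carbon bound to an aromatic nitrogen (butyl to benzyl, when cut one bond further out) gives a 1.8-fold higher number from compound 2 to compound 4 (0.26 log units; within the scatter). As that step lies within the scatter, this position takes a six-membered aromatic ring in place of an open chain with no change that this read-out can separate, at least with the aniline of compound 2. Nothing available here offers a reason for this result.

On these data alone, whether benzyl gives the same result with the aniline of compound 1 or of compound 3 remains open. So does what a longer chain, an amine or a carboxylic acid would do at this position.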